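Shifting the chloro on the anilino ring of compound 1

A few compounds are considered here, and "the series" means these few. Any claim that something is new, unique, unknown or untested is made for them only; others in the source may bear on it.

Three compounds of the series carry a number in a functional assay on the whole organism (strain albino lyka) with Mus musculus as the target, with stated times of 10 min and 30 min; a lower number here means that less compound is needed, a higher number that more compound is needed for the effect. Compound 1 `Clc1ccc(NCCCOc2ccc(-c3cc4ccccc4[nH]3)cc2)cc1` gives 1.8 mg/kg and stands lowest of the three. Compound 3 `COc1ccc(NCCCOc2ccc(-c3cc4ccccc4[nH]3)cc2)cc1` gives 1.9 mg/kg; the step of a 1.1-fold higher number from compound 1 to compound 3 (0.02 log units; within the scatter) shows that methoxy in place of chloro on an aromatic carbon leaves the number essentially unchanged. Within the data shown here, compound 2 `Clc1ccc(NCCCOc2ccccc2-c2cc3ccccc3[nH]2)cc1` gives 7.23 mg/kg, the only number beyond the scatter from compound 1; it differs from compound 1 in how the ether-bearing ring is joined, not in the chlorophenyl part, so it is a change of another kind.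

Compound 4 `Clc1ccccc1NCCCOc1ccc(-c2cc3ccccc3[nH]2)cc1` awaits measurement in this assay. The change from compound 1 is 2-chlorophenyl in place of 4-chlorophenyl on an amine nitrogen. Among the measured compounds shown here, no measured step covers this rearrangement. For the measured compounds named here, the one step on the chlorophenyl part, a 1.1-fold higher number from compound 1 to compound 3 (0.02 log units; within the scatter), concerns what the group is rather than where the chlorine sits, and it was within the scatter. The one rearrangement measured, in compound 2, raised the number, but on the other ring. A modest rise, possibly within the scatter, is therefore expected: a 1.7-fold higher number from compound 1 to compound 4 (0.22 log units; within the scatter). Compound 4 is estimated at 3 mg/kg, with a range from 1.2 mg/kg to 8 mg/kg.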

Compound 4, dose for half-maximal effect: 1.6 mg/kg
For compound 4 the middle estimate is 1.9-fold (0.27 log units) above the measured one; the range from low to high includes it.
By their numbers in this assay, from the lowest: compounds 4, 1 and 3 (each within the scatter of the next); then compound 2.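

In this assay, 2-chlorophenyl in place of 4-chlorophenyl on an amine nitrogen gives a 1.1-fold lower number from compound 1 to compound 4 (0.05 log units; within the scatter), the first measured shift of the chlorine on this ring, and the step lies within the scatter, so the number does not separate these two placements of the chlorine. 2-Chlorophenyl in place of 4-methoxyphenyl on the same nitrogen gives a 1.2-fold lower number from compound 3 to compound 4 (0.07 log units; within the scatter), also within the scatter, so all three aryl groups measured at this position on the shared core sit within the scatter of the next. Among these compounds, compound 2 thus remains the only compound beyond the scatter, and the rearrangement on the chlorophenyl part does not echo the one on the ether-bearing ring. The data shown offer no explanation for this flat result.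

Still open, from the compounds shown here alone, is whether this position stays as flat with an unsubstituted phenyl, or with a carboxylic acid or a dimethylamino group in place of the chloro. Also open, going by these compounds, is whether 2-chlorophenyl gives a similar number on the core of compound 2, or with a longer chain between the amine nitrogen and the ether oxygen.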